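The source may report more compounds than this note shows. Statements on the series, on what has been measured and on what is new or still open speak of the compounds shown alone.

Measured compounds:
compound 1 `CC1CCCN1C1CCN(c2ccc(NC(=O)NC3CCCCC3)cc2)C1` gives 4.1 nM in an assay on CHO cells for displacement of a labelled ligand from histamine receptor H3 (Macaca mulatta), read by scintillation counting, with a stated time of 1 h; a lower number here means a stronger inhibitor, a higher number a weaker inhibitor.
compound 2 `Cc1cc(N2CCC(N3CCCC3C)C2)ccc1NC(=O)NC1CCCCC1` gives 4.6 nM in this assay.
compound 3 `CC1CCCN1C1CCN(c2ccc(NC(=O)Nc3ccc(Oc4ccccc4)cc3)cc2)C1` gives 46.8 nM in this assay.

Compound 1 and compound 2 share one core, and compound 2 carries a change (methyl in place of hydrogen on an aromatic carbon). That change gave a 1.1-fold higher number from compound 1 to compound 2 (0.05 log units; within the scatter), so in this assay the two compounds are not told apart.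

Compound 3 has a different core; how it differs from the core of compound 1 is not broken down here. Its number in this assay is the highest of the three, well beyond the scatter from both compound 1 and compound 2.

Compound 4 `Cc1cc(NC(=O)Nc2ccc(Oc3ccccc3)cc2)ccc1N1CCC(N2CCCC2C)C1` has not yet been measured. It stands to compound 3 as compound 2 stands to compound 1, with a change (methyl in place of hydrogen on an aromatic carbon). The surroundings are not word for word the same: in compound 2 the new group is ortho to a large group, in compound 4 ortho to a 3-(2-methylpyrrolidin-1-yl)pyrrolidin-1-yl group, so this is the same kind of change rather than the same change. Because the earlier step was a 1.1-fold higher number from compound 1 to compound 2 (0.05 log units; within the scatter), the step from compound 3 to compound 4 is expected to be a 1.1-fold higher number from compound 3 to compound 4 (0.03 log units; within the scatter). Compound 4 is thus estimated to give 50 nM in this assay.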

Compound 4, inhibition constant: 115 nM
Estimate against measurement, compound 4: 2.3-fold (0.36 log units) below; low and high end bracket the measured number.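

In this assay, methyl in place of hydrogen on an aromatic carbon, ortho to a 3-(2-methylpyrrolidin-1-yl)pyrrolidin-1-yl group, gave a 2.5-fold higher number from compound 3 to compound 4 (0.39 log units; beyond the scatter), a modest weakening, whereas the same kind of change did not tell compound 1 and compound 2 apart. Set side by side, the two steps are no further apart than repeated measurements of such steps can be: the same change on two cores in this assay, a 1.1-fold higher number (0.05 log units; within the scatter) from compound 1 to compound 2 and a 2.5-fold higher number (0.39 log units; beyond the scatter) from compound 3 to compound 4, 2.2-fold (0.34 log units) apart, within the scatter of two such steps. Among the compounds shown here, this gives no firm sign that the core alters what the methyl does, but two steps cannot prove that the change carries over unaltered, and only the step on the second core lies beyond the scatter.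

The compounds shown leave open how another group at this same place would compare with methyl, such as a chlorine atom, a methoxy group or an ethyl group. They also leave open whether the methyl step would stay this small on a third core.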